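This account rests on a few compounds, and the source may have more. Where it says the series, first, only, none or still open, it means among the compounds named here.

Within the data shown here, in a functional assay on HT-29 cells (Homo sapiens) for antiproliferative activity, read by sulforhodamine B assay, with a stated time of 48 h (on this read-out higher numbers stand for weaker inhibition and lower numbers for stronger inhibition), compound 3 `CCCN1CCN(c2ccc(S(=O)(=O)Oc3ccc(C)cc3C)cc2)C1=O` gives 26000 nM, the higher of the two exact numbers so far. Compound 1 `Cc1ccc(OS(=O)(=O)c2ccc(N3CCN(C)C3=O)cc2)c(C)c1` gives 3000 nM, and the measured change is an 8.7-fold higher number from compound 1 to compound 3 (0.94 log units; beyond the scatter). Compound 2 `CCCN1CCN(c2ccc(S(=O)(=O)Oc3ccccc3C)cc2)C1=O` gives > 100000 nM, which is a limit of the assay and not a number. Compound 4 `CCCN1CCN(c2ccc(S(=O)(=O)Oc3cccc(F)c3)cc2)C1=O` has 3-fluorophenyl in place of 2,4-dimethylphenyl on an oxygen. The closest guide is an at least 3.8-fold lower number from compound 2 to compound 3 (0.58 log units; beyond the scatter), where methyl replaced hydrogen on an aromatic carbon. The change an 8.7-fold higher number from compound 1 to compound 3 (0.94 log units; beyond the scatter) lies at a different place and bears on this less. Compound 4 carries no methyl on the group that changes, so a modest move towards weaker inhibition is expected: a 2.1-fold higher number from compound 3 to compound 4 (0.33 log units; beyond the scatter). For compound 4, the estimated value is 55000 nM, with an expected range of 18000 nM to 150000 nM.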

Compound 4, half-maximal inhibitory concentration: 18000 nM
Estimate against measurement, compound 4: 3.1-fold (0.49 log units) above, and the stated range covers the measured number.
By their numbers in this assay, from the lowest: compound 1; then compounds 4 and 3 (each within the scatter of the next). At a limit, above all of these: compound 2.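

Putting 3-fluorophenyl in place of 2,4-dimethylphenyl on this oxygen gives a 1.4-fold lower number from compound 3 to compound 4 (0.16 log units; within the scatter), so a ring without any methyl can match compound 3, which the earlier methyl step did not reveal. Against the 2-methylphenyl of compound 2, the change gives an at least 5.5-fold lower number from compound 2 to compound 4 (0.74 log units; beyond the scatter). Compound 2 stands at a limit of the assay: the limit of > 100000 nM in this assay, at which 1 of the 4 values shown sits.

The compounds shown leave open what the fluorine contributes on its own. Also open, as far as these compounds go, is how an unsubstituted phenyl or a methoxyphenyl on this oxygen would compare.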